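Replacing the oxygen-bearing ring group of compound 2

The source may report more compounds than this note shows. Statements on the series, on what has been measured and on what is new or still open speak of the compounds shown alone.

For the measured compounds named here, in a physicochemical assay for lipophilicity, using the shake flask method, measured as octanol-water partition, at pH 7.4 (a higher number here means a more lipophilic compound, a lower number a more polar compound), compound 1 `CC(=O)N[C@@H]1CCC[C@H](C(=O)Nc2cc(-c3cnn4c3CCC4)c(Cl)cn2)C1` gives 2.9, while compound 2 `CC(=O)N[C@@H]1CCC[C@H](C(=O)Nc2cc(-c3cnn4c3COCC4)c(Cl)cn2)C1` gives 2.4, the lower of the two numbers so far. Compound 3 `CC(=O)N[C@@H]1CCC[C@H](C(=O)Nc2cc(-c3cnn4c3CC(C)(C)C4)c(Cl)cn2)C1` has not yet been measured. It shares its core with compound 2 and differs in one place, on an aromatic carbon opposite the ring nitrogen: a group of 10 heavy atoms (8 carbon, 2 nitrogen; one five-membered non-aromatic ring with 1 hetero atom, one five-membered aromatic ring with 2 hetero atoms) in place of a group of 9 heavy atoms (6 carbon, 2 nitrogen, 1 oxygen; one five-membered aromatic ring with 2 hetero atoms, one six-membered non-aromatic ring with 2 hetero atoms), on an aromatic carbon. The group that leaves holds one oxygen and a six-membered non-aromatic ring. The group that enters holds no oxygen and has a five-membered non-aromatic ring, the same ring types as the group in compound 1, though it is the larger of those two groups.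

Going by the values given here, only one measured step bears on this change, the modest one of a number 0.50 log units lower from compound 1 to compound 2 (beyond the scatter), which ran between these same ring types in the opposite direction. Its reversal suggests a rise, and the larger entering group suggests a somewhat greater one. Expected in this assay is a number 1.00 log units higher from compound 2 to compound 3 (beyond the scatter), which would lie beyond the scatter. For compound 3 the estimated value is 3.4, with an expected range of 3 to 3.8.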

Compound 3, distribution coefficient: 3.8
Estimate against measurement, compound 3: 0.40 log units below, and the stated range covers the measured number.
By their numbers in this assay, from the lowest: compound 2; then compound 1; then compound 3.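

In this assay, for the compounds shown here, this position, on an aromatic carbon opposite the ring nitrogen, shows a wider span than the earlier pair revealed: the change gives a number 1.40 log units higher from compound 2 to compound 3 (beyond the scatter) and counts as a large step, where the only earlier step was modest. The comparison with compound 1 adds something new, since the ring types stay the same on both sides and the entering group of 10 heavy atoms still gives a number 0.90 log units higher from compound 1 to compound 3 (beyond the scatter) as a modest step, so this position responds to a change in the group even with no change of ring type, and compound 3 now stands highest of the three. No measurement at hand gives a reason for either step.

The step from compound 2 to compound 3 changes the ring size, the oxygen and the group size at once, so the compounds shown cannot divide it among these three. They also leave open how this assay would read for a single methyl group on the five-membered non-aromatic ring, or for a hydroxyl group or an amine carried on that same ring.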